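The compounds below may be only part of what the source reports. "The series", "measured", "known", "first", "only" and "open" are said of these compounds alone.

Measured so far in an assay for inhibition of Polyunsaturated fatty acid 5-lipoxygenase (Homo sapiens), read by HPLC, with stated times of 15 min and 10 min; on this read-out higher numbers stand for weaker inhibition and lower numbers for stronger inhibition:
compound 1 `CCCCC(Sc1nc(Cl)cc(Nc2nc(-c3ccc(Cl)cc3)cs2)n1)C(=O)O` — 900 nM
compound 2 `O=C(O)C(Sc1nc(Cl)cc(Nc2nc(-c3ccc(Cl)cc3)cs2)n1)c1cccc2ccccc12` — 400 nM
compound 3 `CCCCCCC(Sc1nc(Cl)cc(Nc2nc(-c3ccc(C)cc3)cs2)n1)C(=O)O` — 200 nM

In this assay compound 3 gives the lowest of the three numbers. Its gap to compound 2 lies within the scatter of repeated measurements; its gap to compound 1 lies beyond it, so only against compound 1 does compound 3 stand apart.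

Compound 4 `CCCCCCC(Sc1nc(Cl)cc(Nc2nc(-c3ccc(Cl)cc3Cl)cs2)n1)C(=O)O` differs from compound 3 in one place: 2,4-dichlorophenyl in place of 4-methylphenyl on an aromatic carbon. Among the compounds with values here, the single step measured, a 2.3-fold lower number from compound 1 to compound 2 (0.35 log units; beyond the scatter), concerns the saturated chain carbon bound to the carbonyl carbon and the sulfur, a different place from the aromatic carbon changed here. Compounds 1 and 2 differ from compound 3 in more than one place, so their values give no isolated reading of an aryl change. Within the data shown here, no measured step therefore bears on the change from compound 3 to compound 4, and no step beyond the scatter is expected in this assay. Compound 4 is expected at 200 nM, with a range of 70 nM to 600 nM. The expected step, no change at the digits printed from compound 3 to compound 4 (within the scatter), is estimated to lie within the scatter.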

Compound 4, half-maximal inhibitory concentration: 800 nM
Beside the measured number, compound 4's estimate is 4.0-fold (0.60 log units) below it; measured number outside the range, above it.
By their numbers in this assay, from the lowest: compounds 3, 2, 4 and 1 (each within the scatter of the next, the first and the last beyond it).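

In this assay the aryl group on the aromatic carbon next to the ring nitrogen proves sensitive to substitution: a 4.0-fold higher number from compound 3 to compound 4 (0.60 log units; beyond the scatter), a step beyond the scatter. Within the data shown here, this is the first isolated reading at this position, as the earlier step concerned only the saturated chain carbon bound to the carbonyl carbon and the sulfur. Nothing available accounts for the size or direction of this step.

The change from 4-methylphenyl to 2,4-dichlorophenyl alters the aryl substitution in more than one way, so the compounds shown do not assign the step to any single substituent. A 4-chlorophenyl or unsubstituted phenyl group on the side chain of compound 3 would separate these contributions, and a 4-methoxyphenyl group would show whether the trend extends beyond methyl and chlorine.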